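Ester aryl variation on the shared core: compound 4

The source may hold more compounds than are shown below. What is called first, only, known or untested is meant among the compounds shown, and "the series" means these compounds.

Three esters of the shared core carry different aryl groups on the carbonyl carbon. Compound 1 `COc1ccc(C2CC(=NOC(=O)c3ccc([N+](=O)[O-])cc3)CC(c3ccc(OC)cc3)N2C)cc1` gives 280000 nM in a functional assay, with a stated time of 30 min; on this read-out lower numbers stand for stronger inhibition and higher numbers for weaker inhibition. Compound 2 `COc1ccc(C2CC(=NOC(=O)c3ccccc3O)CC(c3ccc(OC)cc3)N2C)cc1` gives 29000 nM in this assay, and compound 3 `COc1ccc(C2CC(=NOC(=O)c3cc(O)c(O)c(O)c3)CC(c3ccc(OC)cc3)N2C)cc1` gives 18000 nM, the lowest number of the three, though the gap is small: a 1.6-fold lower number from compound 2 to compound 3 (0.21 log units; within the scatter), and it lies within the scatter. The wider steps are a 9.7-fold lower number from compound 1 to compound 2 (0.98 log units; beyond the scatter) and a 16-fold lower number from compound 1 to compound 3 (1.19 log units; beyond the scatter).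

Compound 4 `COc1ccc(C2CC(=NOC(=O)c3ccc(OC)cc3OC)CC(c3ccc(OC)cc3)N2C)cc1` differs from compound 3 by 2,4-dimethoxyphenyl in place of 3,4,5-trihydroxyphenyl on a carbonyl carbon. Among the compounds with values here, no measured step swaps hydroxy for methoxy on this ring; the measured steps show only that the hydroxy-bearing aryls give lower numbers than the nitro aryl of compound 1. A modest rise is expected for compound 4, a 2.5-fold higher number from compound 3 to compound 4 (0.40 log units; beyond the scatter), giving an estimated 45000 nM with a range from 12000 nM to 160000 nM.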

Compound 4, half-maximal inhibitory concentration: 80000 nM
For compound 4 the middle estimate is 1.8-fold (0.25 log units) below the measured one; the range from low to high includes it.
By their numbers in this assay, from the lowest: compounds 3 and 2 (each within the scatter of the next); then compound 4; then compound 1.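

The aryl group on the carbonyl carbon needs no hydroxy group to beat 4-nitrophenyl in this assay, with a 3.5-fold lower number from compound 1 to compound 4 (0.54 log units; beyond the scatter). The hydroxy-free 2,4-dimethoxyphenyl nonetheless falls behind both hydroxy-bearing aryls, with a 4.4-fold higher number from compound 3 to compound 4 (0.65 log units; beyond the scatter) and a 2.8-fold higher number from compound 2 to compound 4 (0.44 log units; beyond the scatter). Nothing measured here gives a cause for this order.

As far as these compounds go, it remains open whether the hydroxy groups themselves or their placement on the ring sets the order. From the compounds shown here alone, how an amine or a carboxylic acid on this aryl ring would rank also remains open.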